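Fluorophenyl amine variation in the thioether triazole series

The source may report more compounds than this note shows. Statements on the series, on what has been measured and on what is new or still open speak of the compounds shown alone.

Compound 3 `N#Cc1c(Nc2ccccc2F)nc(SCc2cn(Cc3ccccc3Cl)nn2)nc1-c1ccccc1` gives 5230 nM in a functional assay on B16-F10 cells (Mus musculus) for inhibition, read by MTT assay, with a stated time of 72 h; on this read-out higher numbers stand for weaker inhibition and lower numbers for stronger inhibition. Among the three measured compounds it holds the second highest number. Compound 1 `COc1ccc(Nc2nc(SCc3cn(Cc4ccccc4Cl)nn3)nc(-c3ccccc3)c2C#N)cc1` gives 3990 nM in this assay, and the step of a 1.3-fold higher number from compound 1 to compound 3 (0.12 log units; within the scatter) leaves the two unordered. Compound 2 `Cc1cccc(Nc2nc(SCc3cn(Cc4ccccc4Cl)nn3)nc(-c3ccccc3)c2C#N)c1` gives 13500 nM in this assay; the step of a 2.6-fold lower number from compound 2 to compound 3 (0.41 log units; beyond the scatter) is beyond the scatter, as is a 3.4-fold higher number from compound 1 to compound 2 (0.53 log units; beyond the scatter).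

Compound 4 `N#Cc1c(Nc2ccc(F)cc2)nc(SCc2cn(Cc3ccccc3Cl)nn2)nc1-c1ccccc1` differs from compound 3 in one place: 4-fluorophenyl in place of 2-fluorophenyl on a nitrogen on an aromatic ring. For the measured compounds named here, every measured step changes the aryl group on this same nitrogen, but none keeps the fluorine and only moves it to another place on the ring, so no step bears on the change directly. The steps of a 1.3-fold higher number from compound 1 to compound 3 (0.12 log units; within the scatter) and a 2.6-fold lower number from compound 2 to compound 3 (0.41 log units; beyond the scatter) show that the three aryl groups tried so far span only a modest range in this assay, with compound 2 standing apart from the other two. Moving the fluorine within the same ring is therefore expected to give no step beyond the scatter in this assay, and the step of a 1.2-fold lower number from compound 3 to compound 4 (0.07 log units; within the scatter) is the expected outcome. Compound 4 is expected to give 4500 nM in this assay, with a range from 1800 nM to 11000 nM.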

Compound 4, half-maximal inhibitory concentration: 5340 nM
The estimate for compound 4 lay 1.2-fold (0.07 log units) below the measured number; the range from low to high includes it.
By their numbers in this assay, from the lowest: compounds 1, 3 and 4 (each within the scatter of the next); then compound 2.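

In this assay, for the compounds shown here, the step of a 1.0-fold higher number from compound 3 to compound 4 (0.01 log units; within the scatter) is the first direct reading of where the fluorine sits: on the aryl group carried by this nitrogen, 2-fluorophenyl and 4-fluorophenyl cannot be told apart. Going by these compounds alone, the step of a 1.3-fold higher number from compound 1 to compound 4 (0.13 log units; within the scatter) adds that fluoro and methoxy on this ring also cannot be told apart, while the step of a 2.5-fold lower number from compound 2 to compound 4 (0.40 log units; beyond the scatter) leaves 3-methylphenyl as the one aryl group of the four that stands apart in this assay. Nothing measured here offers an explanation for these results.

The compounds shown hold neither 4-methylphenyl nor 3-fluorophenyl on this nitrogen, so it stays open whether the separation of compound 2 goes with the methyl group itself or with its place on the ring. Also open, on these data alone, is whether a phenyl ring carrying a carboxylic acid or an amine, or a saturated group such as cyclohexyl, on this nitrogen would leave the narrow band held by compound 1, compound 3 and compound 4.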